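The source may report more compounds than this note shows. Statements on the series, on what has been measured and on what is new or still open speak of the compounds shown alone.

Of the compounds shown here, two with a shared core have been measured in a functional assay on HEK293 cells for agonist activity at Bombesin receptor subtype-3 (Homo sapiens), read by luminescence and calcium flux, with a stated time of 10 min; a lower number here means that less compound is needed, a higher number that more compound is needed for the effect. Compound 1 `CCC(C)(C)Cc1c[nH]c(CCc2ccc(-n3ncnn3)cc2)n1` carries a 2H-tetrazol-2-yl group on its outer benzene ring and gives 422 nM. Compound 2 `CCC(C)(C)Cc1c[nH]c(CCc2ccc(-c3ccc(F)cn3)cc2)n1` carries a 5-fluoropyridin-2-yl group at the same place and gives 66 nM. Within the data shown here, the single step between them is a 6.4-fold lower number from compound 1 to compound 2 (0.81 log units; beyond the scatter), so compound 2 stands as the lower of the two numbers, with compound 1 as its only neighbour.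

Compound 3 `CCC(C)(C)Cc1c[nH]c(CCc2ccc(-n3cncn3)cc2)n1` takes the next step: 1H-1,2,4-triazol-1-yl in place of 5-fluoropyridin-2-yl on an aromatic carbon. The entering group is a five-membered ring rich in nitrogen, much like the tetrazole of compound 1, whereas the leaving group of compound 2 is a six-membered pyridine. Among the measured compounds shown here, the only step that bears on this, the one from compound 1 to compound 2, showed that exchanging such an azole for the fluoropyridine lowered the number beyond the scatter. Reversing that kind of exchange is expected to raise the number again, though the triazole is not identical to the tetrazole. Compound 3 is therefore expected to give 300 nM, within a range from 100 nM to 900 nM. The expected change amounts to a 4.5-fold higher number from compound 2 to compound 3 (0.66 log units; beyond the scatter).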

Compound 3, half-maximal effective concentration: 570 nM
Compound 3: the middle estimate sits 1.9-fold (0.28 log units) below what was measured, and the stated range covers the measured number.
By their numbers in this assay, from the lowest: compound 2; then compounds 1 and 3 (each within the scatter of the next).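

In this assay, the group on this aromatic carbon, para to a large group, now has a second five-membered, nitrogen-rich example, and it gives an 8.6-fold higher number from compound 2 to compound 3 (0.94 log units; beyond the scatter) when it replaces the 5-fluoropyridin-2-yl group. Among these compounds, exchanging one five-membered ring for the other gives a 1.4-fold higher number from compound 1 to compound 3 (0.13 log units; within the scatter) and so does not separate 1H-1,2,4-triazol-1-yl from 2H-tetrazol-2-yl, which leaves compound 2 alone with the lowest number of the three, with no compound here going against that split between its six-membered ring and the two five-membered rings. No measurement at hand explains this difference.

The compounds shown leave open whether the lower number of compound 2 goes with the ring size, the ring nitrogen or the fluorine, a question that a plain phenyl ring or a pyridin-2-yl group without fluorine at this place could help to separate. Also open, from the compounds shown here alone, is how a group that is not a ring, such as an amine or a carboxylic acid, would compare here, and whether the same order would hold with a longer chain elsewhere on the shared core.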